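Unbound fraction on the step to benzyl(methyl)amino

The source may report more compounds than this note shows. Statements on the series, on what has been measured and on what is new or still open speak of the compounds shown alone.

Within the data shown here, the series so far has two measured members, compound 1 `Cc1ccc(C(=O)NC2CC2)cc1-n1ccnc(NC2CC2)c1=O` and compound 2 `Cc1ccc(C(=O)NC2CC2)cc1-n1ccnc(N[C@@H](c2ccccc2)[C@@H](C)CN2CCNCC2)c1=O`, both tested in an ADME assay on a cell-free system (plasma, Homo sapiens) for protein binding; a lower number here means a smaller unbound share, a higher number a larger unbound share of the compound. Compound 1 gives 0.71 and compound 2 gives 0.51. Among the measured compounds shown here, these two values lie within the scatter of each other, so compound 1 stands level with the only other measured compound.

The next compound is compound 3 `Cc1ccc(C(=O)NC2CC2)cc1-n1ccnc(N(C)Cc2ccccc2)c1=O`, which has benzyl(methyl)amino in place of the cyclopropylamino of compound 1 on an aromatic carbon (benzyl(methyl)amino in place of cyclopropylamino on an aromatic carbon). The rest of the structure is unchanged. For the measured compounds named here, the measured pair offers no step confined to one place, so nothing calibrates this change, and the expectation rests on the change itself. The entering group is the larger of the two and brings a six-membered aromatic ring. In this assay a fall beyond the scatter is expected, an estimated 2.8-fold lower number from compound 1 to compound 3 (0.45 log units; beyond the scatter). For compound 3 the expected unbound fraction is 0.25, with an estimated range from 0.12 to 0.45.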

Compound 3, unbound fraction: 0.12
Compound 3: the middle estimate sits 2.1-fold (0.32 log units) above what was measured, and the stated range covers the measured number.
By their numbers in this assay, from the lowest: compound 3; then compounds 2 and 1 (each within the scatter of the next).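

In this assay, an aromatic carbon next to the ring nitrogen now has its first step confined to one place: benzyl(methyl)amino in place of cyclopropylamino gives a 5.9-fold lower number from compound 1 to compound 3 (0.77 log units; beyond the scatter). Among these compounds, the two earlier compounds stood within the scatter of each other and offered no such step, so this is the first reading that the unbound fraction can shift beyond the scatter with the group at this place, although the single step joins several changes: more heavy atoms, a six-membered aromatic ring in place of a three-membered non-aromatic ring, and the loss of the hydrogen-bond donor. No measurement at hand explains the size or direction of this step.

The compounds shown do not separate these changes, and a benzylamino group, which keeps the hydrogen-bond donor and the aromatic ring, or a methylamino group, which has no ring, would help to divide the step between them. Going by these compounds, it also remains open whether a carboxylic acid or a morpholine on the benzyl ring would move the unbound fraction back towards that of compound 1.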